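This account rests on a few compounds, and the source may have more. Where it says the series, first, only, none or still open, it means among the compounds named here.

Working notes on the series.

Compound 3 `CC1=NC(C)=C(C(=O)O)C(c2cccc(F)c2)/C1=C(\O)OC/C=C/c1ccccc1` gives 1300 nM in a functional assay on IMR-32 cells for inhibition of Voltage-dependent N-type calcium channel subunit alpha-1B (Homo sapiens), read by calcium flux (on this read-out higher numbers stand for weaker inhibition and lower numbers for stronger inhibition), and stands lowest of the three numbers in hand. Compound 1 `CC1=NC(C)=C(C(=O)O)C(c2ccccc2[N+](=O)[O-])/C1=C(\O)OC/C=C/c1ccccc1` gives 37000 nM in this assay, and compound 2 `CC1=NC(C)=C(C(=O)O)C(c2ccc([N+](=O)[O-])cc2)/C1=C(\O)OC/C=C/c1ccccc1` gives 21000 nM. Between the two nitrophenyl compounds the change is a 1.8-fold lower number from compound 1 to compound 2 (0.25 log units; within the scatter). Replacing the nitrophenyl by 3-fluorophenyl brought a 28-fold lower number from compound 1 to compound 3 (1.45 log units; beyond the scatter) and a 16-fold lower number from compound 2 to compound 3 (1.21 log units; beyond the scatter), so the 3-fluorophenyl is clearly the better substituent on the saturated ring carbon among these three.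

Compound 4 `CC1=NC(C)=C(C(=O)O)C(c2cccc(I)c2)/C1=C(\O)OC/C=C/c1ccccc1` carries iodo in place of fluoro on an aromatic carbon. Among the compounds with values here, none of the measured steps exchanges one halogen for another at this place; all of them swap the whole nitrophenyl group for the fluorophenyl, so they give no direct reading on a fluoro-to-iodo change. The only guidance is that a halogen at this position is compatible with the strongest number so far, shown by compound 3 with 1300 nM. A change of no more than modest size is therefore expected in this assay, with the direction open; the expected step is a 1.3-fold lower number from compound 3 to compound 4 (0.11 log units; within the scatter). Compound 4 is estimated at 1000 nM, within a range from 250 nM to 4000 nM.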

Compound 4, half-maximal inhibitory concentration: 1700 nM
Beside the measured number, compound 4's estimate is 1.7-fold (0.23 log units) below it, within the range that was stated.
By their numbers in this assay, from the lowest: compounds 3 and 4 (each within the scatter of the next); then compounds 2 and 1 (each within the scatter of the next).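

In this assay iodo in place of fluoro on the aromatic carbon gives a 1.3-fold higher number from compound 3 to compound 4 (0.12 log units; within the scatter) and so shows that this place, meta to a large group, takes either halogen without a step beyond the scatter. The 3-iodophenyl also holds the separation from both nitrophenyl compounds, with a 12-fold lower number from compound 2 to compound 4 (1.09 log units; beyond the scatter) and a 22-fold lower number from compound 1 to compound 4 (1.34 log units; beyond the scatter) as well, so that separation is not particular to the 3-fluorophenyl. No measurement at hand accounts for these readings.

Open, from the compounds shown here alone, is how a methoxy or an amine on this same aromatic carbon would read against the two halogens in this assay and whether a chloro or bromo would fall with them. Also open, going by these compounds, is whether a methyl ester in place of the carboxylic acid on the shared core would keep these numbers.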